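The source may report more compounds than this note shows. Statements on the series, on what has been measured and on what is new or still open speak of the compounds shown alone.

Among the measured compounds shown here, compound 2 `CC(C)n1ncc2c(C(=O)Nc3cc(C(N)=O)ccc3F)cc(-c3cccs3)nc21` stands as the only compound with a measured number in an ADME assay on LLC-MK2 cells (Macaca mulatta) for cytotoxicity, read by spectrophotometry and crystal violet staining, with a stated time of 4 days (a lower number here means that less compound is tolerated, a higher number that more compound is tolerated), where compound 2 gives 25000 nM. Compound 1 `CC(C)n1ncc2c(C(=O)Nc3cccnc3)cc(-c3cccs3)nc21` sits at the assay limit of > 200000 nM, which is a limit and not a number. For the measured compounds named here, the one measured step, an at least 8.0-fold lower number from compound 1 to compound 2 (0.90 log units; beyond the scatter), bears on the change now considered, and it starts from the limit of > 200000 nM in this assay, at which 1 of the 2 values shown sits. Compound 3 `CC(C)n1ncc2c(C(=O)Nc3ccc(F)cn3)cc(-c3cccs3)nc21` differs from compound 2 by 5-fluoropyridin-2-yl in place of 5-carbamoyl-2-fluorophenyl on an amide-type nitrogen, a move back toward a pyridine-type ring as the pyridin-3-yl of compound 1 carried. The expected step is a 4.0-fold higher number from compound 2 to compound 3 (0.60 log units; beyond the scatter), a reversal of much of that measured step. Compound 3 is estimated in this assay at 100000 nM, between 30000 nM and 200000 nM.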

Compound 3, half-maximal cytotoxic concentration: > 200000 nM
Compound 3: no number, only a limit; the forecaster's own chance of this, stated with the estimate: 45%; middle value at least 2.0-fold (0.30 log units) from the limit.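

Putting 5-fluoropyridin-2-yl in place of 5-carbamoyl-2-fluorophenyl on the amide-type nitrogen gives an at least 8.0-fold higher number from compound 2 to compound 3 (0.90 log units; beyond the scatter) in this assay. A second pyridine-type ring thus also stands at the limit, and among the three compounds only compound 2 gives a number: the limit of > 200000 nM in this assay, at which 2 of the 3 values shown sit. The values of compound 1 and compound 3 are both limits, so the step between them cannot be read. Still open, on these data alone, is whether the carbamoyl or the fluorine of 5-carbamoyl-2-fluorophenyl goes with the lower number, and what a carboxylic acid or an amine in place of the carbamoyl would give in this assay.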